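This account rests on a few compounds, and the source may have more. Where it says the series, first, only, none or still open, it means among the compounds named here.

Working notes on the series, read in a functional assay on A549 cells (Homo sapiens) for inhibition; on this read-out lower numbers stand for stronger inhibition and higher numbers for weaker inhibition. Within the data shown here, compound 1 `COc1cc2ccc(CCc3ccc4ccccc4c3)cc2cc1O` is the only member with a true number, at 3590 nM. Compound 2 `COc1ccc(/C=C\c2ccc3ccccc3c2)cc1[N+](=O)[O-]` gives > 20000 nM, which is a limit of the assay and not a number. Compound 3 `C(=C\c1ccc2[nH]ccc2c1)\c1ccc2ccccc2c1` gives > 5000 nM, likewise only a limit. Among the measured compounds shown here, compound 3 therefore has no exact position, and no measured pair shows what a single change does in this assay.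

The next compound is compound 4 `Cn1ccc2cc(/C=C\c3ccc4ccccc4c3)ccc21`, which differs from compound 3 by methyl in place of hydrogen on an aromatic nitrogen. For the measured compounds named here, with no measured step to draw on, the expectation rests on the limit of > 5000 nM for compound 3. No large gain is expected from so small a change, and any shift is expected to stay near the scatter, tilting slightly towards weaker inhibition. The expected step that the limit leaves unreadable from compound 3 to compound 4 is correspondingly modest. The estimate for compound 4 is 8000 nM, with an expected range of 2000 nM to 30000 nM.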

Compound 4, half-maximal inhibitory concentration: > 5000 nM
Compound 4 ended at the assay's limit; the forecaster's own chance of this, stated with the estimate: 55%; the middle value lies beyond the limit too.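

In this assay, among these compounds, compound 3 and compound 4 both end at a limit of the assay and not at a number, so no step between them can be read: the limit of > 5000 nM in this assay, at which 2 of the 4 values shown sit. The compounds shown leave open whether methyl in place of hydrogen on an aromatic nitrogen changes inhibition at all.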